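Swapping Chloro for Trifluoromethyl in a Diaryl Urea

The source may report more compounds than this note shows. Statements on the series, on what has been measured and on what is new or still open speak of the compounds shown alone.

Compound 2 `Cc1ccc(NC(=O)Nc2ccc(Cl)c(Cl)c2)cc1NC(=O)c1ccccc1` sits at the weak end of the three measured compounds: in a functional assay on A375P cells (Homo sapiens) for antiproliferative activity (a lower number here means a stronger inhibitor, a higher number a weaker inhibitor), compound 2 gives 5800 nM. Compound 1 `CC(=O)Nc1cc(NC(=O)Nc2ccc(Cl)c(C(F)(F)F)c2)ccc1C` gives 1100 nM in this assay, and compound 3 `Cc1ccc(NC(=O)Nc2cc(Cl)cc(Cl)c2)cc1NC(=O)c1ccccc1` gives 259 nM. Among the compounds with values here, the only measured step, a 22-fold lower number from compound 2 to compound 3 (1.35 log units; beyond the scatter), concerns a change of the chloro pattern on one ring and does not isolate the swap considered here. Compound 4 `Cc1ccc(NC(=O)Nc2ccc(Cl)c(C(F)(F)F)c2)cc1NC(=O)c1ccccc1` differs from compound 2 by trifluoromethyl in place of chloro on an aromatic carbon. Within the data shown here, no measured pair tests this exact exchange. Compound 1 carries the same chloro and trifluoromethyl pattern as compound 4 but a different amide group elsewhere in the molecule, so its value can only hint at the direction, and its number does lie well under that of compound 2. Compound 4 is therefore expected to give a moderately lower number than compound 2. The expected step is a 2.3-fold lower number from compound 2 to compound 4 (0.37 log units; beyond the scatter). Compound 4 is estimated at 2500 nM, with a range from 800 nM to 8000 nM.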

Compound 4, half-maximal inhibitory concentration: 1300 nM
Compound 4: the middle estimate sits 1.9-fold (0.28 log units) above what was measured; the measured number falls inside the stated range.
By their numbers in this assay, from the lowest: compound 3; then compounds 1 and 4 (each within the scatter of the next); then compound 2.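

In this assay the exchange of chloro for trifluoromethyl, on an aromatic carbon ortho to a chloro group, now has a direct test: a 4.5-fold lower number from compound 2 to compound 4 (0.65 log units; beyond the scatter). Compound 1 could only hint at this direction, whereas this pair differs in that one place alone. With trifluoromethyl in place, phenyl instead of methyl on a carbonyl carbon gives a 1.2-fold higher number from compound 1 to compound 4 (0.07 log units; within the scatter), so these two amide groups cannot be told apart in this read-out, and nothing shown here explains either step.

From the compounds shown here alone, it remains open how other groups on this aromatic carbon, such as a nitrile, a methoxy group or a bromine, would compare with trifluoromethyl. Also open, going by these compounds, is whether the same exchange would have a similar effect on the chloro pattern of compound 3.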